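This account rests on a few compounds, and the source may have more. Where it says the series, first, only, none or still open, it means among the compounds named here.

Of the compounds shown here, three built on a shared core have been measured in a functional assay on PC-3 cells (Homo sapiens) for inhibition, read by sulforhodamine B assay, with a stated time of 48 h, tested at 10 uM; a higher number here means a weaker effect of the compound at the concentration tested, a lower number a stronger effect. Compound 1 `COc1cc(Cl)cc(-c2nn(-c3cccc(NC(=O)Nc4ccc(Cl)c(C(F)(F)F)c4)c3)cc2-c2ccncc2)c1` gives -13%. Compound 2 `COc1cc(Cl)cc(-c2nn(-c3cccc(NC(=O)c4cccc(C(F)(F)F)c4)c3)cc2-c2ccncc2)c1` gives 23.1%. Compound 3 `O=C(Nc1cccc(-n2cc(-c3ccncc3)c(-c3cc(O)cc(Cl)c3)n2)c1)c1cc(C(F)(F)F)cc(C(F)(F)F)c1` gives 21.7%, the second highest of the three numbers, within the scatter of compound 2 and well apart from compound 1. Going by the values given here, the only measured step, a number 36.1 percentage points higher from compound 1 to compound 2 (beyond the scatter), swaps the group on the carbonyl carbon and says nothing about the part altered here. Compound 4 `COc1cc(Cl)cc(-c2nn(-c3cccc(NC(=O)c4cc(C(F)(F)F)cc(C(F)(F)F)c4)c3)cc2-c2ccncc2)c1` differs from compound 3 by methyl in place of hydrogen on an oxygen on an aromatic ring. Among the compounds with values here, no measured step touches this oxygen, so nothing supports a shift beyond the scatter, and a number 1.7 percentage points lower from compound 3 to compound 4 (within the scatter) is the expected step. Compound 4 is estimated at 20%, within 0% to 40%.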

Compound 4, a percentage reported as activity, at one concentration (the size of the read-out at that concentration, not a potency): 35.6%
Compound 4: the middle estimate sits 15.6 percentage points below what was measured, and the stated range covers the measured number.
By their numbers in this assay, from the lowest: compound 1; then compounds 3 and 2 (each within the scatter of the next); then compound 4.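

Turning hydroxy into methoxy, on an oxygen on an aromatic ring, gives a number 13.9 percentage points higher from compound 3 to compound 4 (beyond the scatter) in this assay and so a weaker effect, the first sign that this oxygen matters. Trifluoromethyl in place of hydrogen on an aromatic carbon gives a number 12.5 percentage points higher from compound 2 to compound 4 (beyond the scatter) and also weakens the effect. As far as these compounds go, whether an amine or a longer chain such as ethoxy in this place would behave like hydroxy or like methoxy stays open. Nothing available explains either step.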